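A few compounds are considered here, and "the series" means these few. Any claim that something is new, unique, unknown or untested is made for them only; others in the source may bear on it.

Measured compounds:
Compound 2 `COc1cc(-c2nnc(SCC(=O)c3ccc(Cl)cc3)n2N2C(=O)c3ccccc3C2=O)cc(OC)c1OC` — 20700 nM
Compound 1 `CCCc1nnc(SCC(=O)c2ccccc2)n1N1C(=O)c2ccccc2C1=O` — > 200000 nM

Among the measured compounds shown here, in a functional assay on PC-3M cells (Homo sapiens) for cytotoxicity, read by MTT assay, with a stated time of 48 h (a lower number here means a stronger inhibitor, a higher number a weaker inhibitor), compound 2 gives 20700 nM, the only actual number among the two results at hand. For compound 1 the result is a limit of the assay, (the limit of > 200000 nM in this assay, at which 1 of the 2 values shown sits), so no number stands against it. For the measured compounds named here, compound 2 therefore stands alone as the one compound with a measured concentration, and nothing can be said of an ordered gap between it and compound 1 beyond what the two values show.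

Compound 3 `COc1cc(-c2nnc(SCC(=O)c3ccccc3)n2N2C(=O)c3ccccc3C2=O)cc(OC)c1OC` has not yet been tested in this assay. It differs from compound 2 in one place: hydrogen in place of chloro on an aromatic carbon. Going by the values given here, no pair of measured compounds shows this change, so its effect here is untested. The expectation is a modest weakening, a step from compound 2 to compound 3 of about a 1.9-fold higher number from compound 2 to compound 3 (0.29 log units; within the scatter), somewhat beyond the usual scatter but not far. Compound 3 is accordingly estimated at 40000 nM, with a likely range from 15000 nM to 120000 nM.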

Compound 3, half-maximal inhibitory concentration: > 200000 nM
Compound 3: only a limit was reported; the forecaster's own chance of this, stated with the estimate: 15%; at least 5.0-fold (0.69 log units) between middle value and limit.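

In this assay, the one measured concentration among these compounds proves to depend on the 4-chlorophenyl group: with hydrogen entering in place of chloro on the aromatic carbon para to a large group, the result is an at least 9.6-fold higher number from compound 2 to compound 3 (0.98 log units; beyond the scatter). Compound 3 gives only a limit of the assay, > 200000 nM, so this step has a lower bound but no exact size. The step from compound 1 to compound 3, with 3,4,5-trimethoxyphenyl in place of propyl, cannot be read, and the 3,4,5-trimethoxyphenyl group on its own, without the chloro, does not yield a measured number here: the limit of > 200000 nM in this assay, at which 2 of the 3 values shown sit.

On these data alone, it remains open whether the effect belongs to chloro in particular, or whether fluoro, bromo or methoxy on the same aromatic carbon would keep the potency of compound 2. As far as these compounds go, it is also open whether the 4-chlorophenyl group would give a measured number alongside propyl, a longer chain or an amine in place of the 3,4,5-trimethoxyphenyl group.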